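The compounds below may be only part of what the source reports. "The series", "measured", "known", "first", "only" and "open" are said of these compounds alone.

Compound 1 `Oc1cc(-c2ccc3ccccc3c2)nc2ncccc12` is the starting point. In a functional assay on U-251 cells (Homo sapiens) for antiproliferative activity (a higher number here means a weaker inhibitor of growth, a lower number a stronger inhibitor of growth), compound 1 gives 4370 nM. Compound 2 `Cc1ccnc2nc(-c3cccc4ccccc34)cc(O)c12` carries the same hydroxyl but a different core and a methyl. For compound 2 this assay reports only a limit of < 10 nM. Compound 3 `Cc1cc(C)c2c(O)cc(-c3cccc4ccccc34)nc2n1` adds a second methyl and in this assay gives 372 nM. The change between them is methyl in place of hydrogen on an aromatic carbon and it made an at least 37-fold higher number from compound 2 to compound 3 (1.57 log units; beyond the scatter); the step can only be given as a lower bound because of the limit of < 10 nM in this assay, at which 1 of the 3 values shown sits. How the cores of compound 1 and compound 2 differ is not broken down here.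

Compound 4 `Cc1ccc2c(O)cc(-c3ccc4ccccc4c3)nc2n1` has not yet been measured. Next to compound 1 it shows (methyl in place of hydrogen on an aromatic carbon). Around the place, the only difference from the earlier case is that there the new methyl was also meta to a methyl group, so this is the same kind of change. Going by the values given here, from compound 1 to compound 4 a step of a 2.2-fold lower number from compound 1 to compound 4 (0.34 log units; beyond the scatter) is expected, resting on the single earlier methyl step and on the position of compound 1 in this assay. For compound 4 the estimate is 2000 nM, between 200 nM and 15000 nM.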

Compound 4, concentration for 50% growth inhibition: 4570 nM
The estimate for compound 4 lay 2.3-fold (0.36 log units) below the measured number, within the range that was stated.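

Swapping hydrogen for methyl on an aromatic carbon of the core of compound 1 leaves the result in this assay effectively unchanged, with a 1.0-fold higher number from compound 1 to compound 4 (0.02 log units; within the scatter). The same swap therefore cannot be assumed to do the same thing on a different core, because its effect differed clearly between the two cores: the same change on two cores in this assay, an at least 37-fold higher number (1.57 log units; beyond the scatter) from compound 2 to compound 3 and a 1.0-fold higher number (0.02 log units; within the scatter) from compound 1 to compound 4, at least 35-fold (1.55 log units) apart, beyond the scatter of two such steps

These two pairs do not show which difference between the cores matters or why, and the size of the larger step remains uncertain, as it is only a lower bound set by a limit: the limit of < 10 nM in this assay, at which 1 of the 4 values shown sits.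

The compounds shown leave open how an ethyl chain or an amine would behave at this place on the core of compound 1, next to the ring nitrogen. On these data alone, it is also open whether a methoxy group in place of the hydroxyl shared by all four compounds would keep or alter their growth inhibition.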